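A Phenyl Group Replaces 3-Ethoxy-4-hydroxyphenyl

A few compounds are considered here, and "the series" means these few. Any claim that something is new, unique, unknown or untested is made for them only; others in the source may bear on it.

Within the data shown here, in a functional assay on DLD-1 cells (Homo sapiens) for cytotoxicity, read by MTT assay (a higher number here means a weaker inhibitor, a lower number a stronger inhibitor), compound 3 (`CCOc1cc(C=C(C(=O)/C=C/c2ccc(O)c(OCC)c2)C(=O)/C=C/c2ccc(O)c(OCC)c2)ccc1O`) gives 1360 nM, the lowest of the three numbers measured so far. Compound 1 (`COc1cc(/C=C/C(=O)C(=Cc2ccc(OC)c(OC)c2)C(=O)/C=C/c2ccc(O)c(OC)c2)ccc1O`) gives 3070 nM, and compound 2 (`COc1cc(/C=C/C(=O)C(=Cc2ccc(O)c(O)c2)C(=O)/C=C/c2ccc(O)c(OC)c2)ccc1O`) gives 17600 nM. Compound 4 (`CCOc1cc(/C=C/C(=O)C(=Cc2ccccc2)C(=O)/C=C/c2ccc(O)c(OCC)c2)ccc1O`) is the next to be considered. It differs from compound 3 by one change, phenyl in place of 3-ethoxy-4-hydroxyphenyl on a double-bonded chain carbon bound to a double-bonded chain carbon.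

Among the measured compounds shown here, only one measured step touches this place, a 5.7-fold higher number from compound 1 to compound 2 (0.76 log units; beyond the scatter). It exchanges different groups from those here, so it shows that this assay responds to changes at this place but gives only weak guidance on direction. For the measured compounds named here, no measured compound carries phenyl there. A small rise in the number is therefore expected, possibly no larger than the scatter, and the estimated step is a 1.5-fold higher number from compound 3 to compound 4 (0.17 log units; within the scatter). The expected value for compound 4 is 2000 nM, within an estimated range of 700 nM to 6000 nM.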

Compound 4, half-maximal inhibitory concentration: 5060 nM
The estimate for compound 4 lay 2.5-fold (0.40 log units) below the measured number; the measured number falls inside the stated range.
By their numbers in this assay, from the lowest: compound 3; then compounds 1 and 4 (each within the scatter of the next); then compound 2.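

In this assay the change to phenyl gives a 3.7-fold higher number from compound 3 to compound 4 (0.57 log units; beyond the scatter), so at this place, on a double-bonded chain carbon bound to a double-bonded chain carbon, replacing 3-ethoxy-4-hydroxyphenyl with the unsubstituted ring costs more than the scatter. Earlier, only an exchange of one substituted ring for another had been seen here; this step shows that removing the substituents altogether also raises the number, although compound 4 keeps a measurable value. Nothing available explains this rise.

Whether the ethoxy group, the hydroxyl group or both account for the rise remains open, and 3-ethoxyphenyl and 4-hydroxyphenyl at this place would separate them. From the compounds shown here alone, how an amine or a carboxylic acid on this ring would read in this assay also remains open.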